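This account rests on a few compounds, and the source may have more. Where it says the series, first, only, none or still open, it means among the compounds named here.

In a functional assay on A549 cells (Homo sapiens) for antiproliferative activity, read by MTT assay, with a stated time of 48 h (on this read-out higher numbers stand for weaker inhibition and lower numbers for stronger inhibition), compound 1 `COc1cc(-c2cccc3nc(-c4ccccc4)oc23)cc(OC)c1OC` gives 20300 nM and compound 2 `COc1ccc(-c2nc3cccc(-c4cc(OC)c(OC)c(OC)c4)c3o2)cc1` gives 2200 nM, the lower of the two numbers. Compound 3 `COc1cccc(-c2nc3cccc(-c4cc(OC)c(OC)c(OC)c4)c3o2)c1` differs from compound 2 by 3-methoxyphenyl in place of 4-methoxyphenyl on an aromatic carbon. Among the measured compounds shown here, only one measured step bears on this change: methoxy in place of hydrogen on an aromatic carbon gave a 9.2-fold lower number from compound 1 to compound 2 (0.97 log units; beyond the scatter), which is beyond the scatter and modest in size. From that step, a smaller rise towards a higher number is expected in this assay. The estimated change is a 2.3-fold higher number from compound 2 to compound 3 (0.36 log units; beyond the scatter). For compound 3 the expected value is 5000 nM, within an estimated range of 1600 nM to 15000 nM.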

Compound 3, half-maximal inhibitory concentration: 3500 nM
For compound 3 the middle estimate is 1.4-fold (0.15 log units) above the measured one; low and high end bracket the measured number.
By their numbers in this assay, from the lowest: compounds 2 and 3 (each within the scatter of the next); then compound 1.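

In this assay, 3-methoxyphenyl in place of 4-methoxyphenyl on the aromatic carbon next to the ring nitrogen and next to the ring oxygen gives a step within the scatter (a 1.6-fold higher number from compound 2 to compound 3 (0.20 log units; within the scatter)), so these two placements of the methoxy cannot be told apart here. Methoxy in place of hydrogen on that phenyl ring also gives a step beyond the scatter in the new placement (a 5.8-fold lower number from compound 1 to compound 3 (0.76 log units; beyond the scatter)), so the lower number is no longer seen with 4-methoxyphenyl alone. Open, as far as these compounds go, is how an amine or a carboxylic acid would read in place of the methoxy on that ring. No measured evidence here accounts for either step.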